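Benzisoxazole in Place of Methylcarbamoyl: Expected Cytotoxicity

The compounds below may be only part of what the source reports. "The series", "measured", "known", "first", "only" and "open" are said of these compounds alone.

Measured compounds:
compound 1 `CNC(=O)c1ccc(NCc2cncn2Cc2ccc(-c3ccccc3)cc2N)cc1-c1ccccc1` — in a toxicity assay on NIH3T3 cells (Mus musculus) for cytotoxicity, read by resazurin assay (on this read-out lower numbers stand for an effect already at smaller amounts and higher numbers for an effect only at larger amounts of compound), compound 1 gives > 1000 nM, a limit of the assay.
compound 2 `CNC(=O)c1ccc(NCc2cncn2Cc2ccc(-c3ccccc3)cc2)cc1-c1ccccc1` — in this assay compound 2 gives > 1000 nM, again a limit.
compound 3 `c1ccc(Cn2cncc2CNc2cccc(-c3ccccc3)c2)cc1` — in this assay compound 3 gives > 750 nM, also a limit.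

Compound 2 therefore stands at a limit in this assay and not at a number, and the two other values shown are limits as well. Among the compounds with values here, the single step between measured compounds, a step that the two limits leave unreadable from compound 1 to compound 2, cannot be read because a step that the two limits leave unreadable from compound 1 to compound 2 runs between two limits. The evidence thus reduces to the limit of > 1000 nM in this assay, at which 2 of the 3 values shown sit, and (the limit of > 750 nM in this assay, at which 1 of the 3 values shown sits).

The unmeasured compound 4 `c1ccc(-c2ccc(Cn3cncc3CNc3ccc(-c4onc5ccccc45)c(-c4ccccc4)c3)cc2)cc1` differs from compound 2 in one place: a group of 9 heavy atoms (7 carbon, 1 nitrogen, 1 oxygen; one five-membered aromatic ring with 2 hetero atoms, one six-membered aromatic ring of carbon only) in place of a group of 4 heavy atoms (2 carbon, 1 nitrogen, 1 oxygen; no ring), on an aromatic carbon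

Within the data shown here, no measured step bears on this change, since every value shown is a limit. What can be said is that all three measured compounds, including compound 2, stay at the limits of this assay. On that basis compound 4 is expected to give about 2000 nM in this assay, with a range from 700 nM to 6000 nM. The step that the limit leaves unreadable from compound 2 to compound 4 is accordingly expected to be no larger than the scatter, with a fair chance that compound 4 again reports only a limit.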

Compound 4, half-maximal effective concentration: > 10000 nM
Compound 4: a limit, no number (the forecaster's own chance of this, stated with the estimate: 65%); middle value at least 5.0-fold (0.69 log units) from the limit.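

In this assay compound 4 gives > 10000 nM, a limit of the assay and not a number. Within the data shown here, compound 2 and compound 4 both stand at limits, and no step between them can be read. The compounds shown leave open at what amount each would take effect, and whether exchanging the methylcarbamoyl group changes that amount at all.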